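A few compounds are considered here, and "the series" means these few. Any claim that something is new, unique, unknown or untested is made for them only; others in the source may bear on it.

Of the compounds shown here, three built on one shared core have been measured in a functional assay on T47D cells (Homo sapiens) for cytotoxicity, read by MTT assay, with a stated time of 48 h; on this read-out higher numbers stand for weaker inhibition and lower numbers for stronger inhibition. Compound 1 `C=CCNC(=S)N/N=C\c1ccnc2ccccc12` gives 1230 nM, compound 2 `S=C(N/N=C\c1ccnc2ccccc12)Nc1ccc(Br)cc1` gives 1480 nM, and compound 3 `S=C(N/N=C\c1ccnc2ccccc12)Nc1ccccc1` gives 1380 nM. The three numbers sit in a narrow band: the steps of a 1.2-fold higher number from compound 1 to compound 2 (0.08 log units; within the scatter), a 1.1-fold higher number from compound 1 to compound 3 (0.05 log units; within the scatter) and a 1.1-fold lower number from compound 2 to compound 3 (0.03 log units; within the scatter) are each within the scatter, so compound 3 cannot be told apart from compound 1 or compound 2 on these numbers; it simply sits in the middle of the band.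

Compound 4 `COc1ccc(NC(=S)N/N=C\c2ccnc3ccccc23)cc1` has not yet been measured. Its difference from compound 3 is methoxy in place of hydrogen on an aromatic carbon. The step that bears most directly on this change is a 1.1-fold lower number from compound 2 to compound 3 (0.03 log units; within the scatter), which also exchanged a group for hydrogen on an aromatic carbon and left the number essentially unchanged. The larger exchange a 1.1-fold higher number from compound 1 to compound 3 (0.05 log units; within the scatter), replacing allyl with phenyl, did likewise. For the measured compounds named here, nothing among the measured compounds therefore points to a move beyond the scatter in this assay for compound 4 in either direction. The expected step is a 1.0-fold higher number from compound 3 to compound 4 (0.01 log units; within the scatter). Compound 4 is estimated to give about 1400 nM in this assay, with a range from 700 nM to 2800 nM.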

Compound 4, half-maximal inhibitory concentration: 1360 nM
For compound 4 the middle estimate is 1.0-fold (0.01 log units) above the measured one; the range from low to high includes it.
By their numbers in this assay, from the lowest: compounds 1, 4, 3 and 2 (each within the scatter of the next).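

In this assay the aromatic carbon para to a large group has now carried hydrogen, bromo and methoxy, and the number stays put across all three: there is a 1.0-fold lower number from compound 3 to compound 4 (0.01 log units; within the scatter) and also a 1.1-fold lower number from compound 2 to compound 4 (0.04 log units; within the scatter) even though methoxy brings an oxygen atom and a hydrogen-bond acceptor that neither earlier group has. The new compound also extends the earlier comparison with the allyl group on the amide-type nitrogen, since there is a 1.1-fold higher number from compound 1 to compound 4 (0.04 log units; within the scatter) and so a substituted phenyl at that nitrogen cannot be told apart from allyl either. Nothing available here explains why these four numbers stay so close together.

Going by these compounds, whether an amine or a carboxylic acid on this same aromatic carbon would shift the number beyond the scatter remains open, as does the effect of a longer chain in place of the allyl group of compound 1. All four compounds also keep the same core and the same thiocarbonyl, so these results say nothing about how much either of those parts contributes to the cytotoxicity.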